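A Shared Acidic Group Replaced in Compound 4

This account rests on a few compounds, and the source may have more. Where it says the series, first, only, none or still open, it means among the compounds named here.

Compound 1 `COc1cc(C(=O)NS(=O)(=O)c2ccccc2C)ccc1Cn1ncc2ccc(NC(=O)OC3CCCC3)cc21` gives 10.2 in a functional assay (trachea) for antagonist activity, with Cavia porcellus as the target; a higher number here means a more potent compound, by a factor of ten per unit of this negative logarithm, a lower number a less potent compound.
Compound 2 `CCCCC(CC)C(=O)Nc1ccc2ccn(Cc3ccc(C(=O)NS(=O)(=O)c4ccccc4C)cc3OC)c2c1` gives 8.9 in this assay.
Compound 3 `COc1cc(C(=O)NS(=O)(=O)c2ccccc2C)ccc1Cn1ccc2ccc(NC(=O)CC3CCCC3)cc21` gives 9.9 in this assay.

Compound 2 holds the lowest of the three numbers. Compound 3 stands nearest to it, and compound 1 stands furthest, both above it and both beyond the scatter. For the measured compounds named here, the only step measured between two neighbours is a number 1.00 log units higher from compound 2 to compound 3 (beyond the scatter); it alters the chain on a carbonyl carbon of the amide and leaves the rest of the shared core untouched.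

Compound 4 `CCCCC(CC)C(=O)Nc1ccc2ccn(Cc3ccc(C(=O)C(C#N)S(=O)(=O)c4ccccc4)cc3OC)c2c1` differs from compound 2 in another part of the molecule: cyano(phenylsulfonyl)methyl in place of ((2-methylphenyl)sulfonyl)amino on a carbonyl carbon. Going by the values given here, all three measured compounds carry the same ((2-methylphenyl)sulfonyl)amino group on that carbonyl carbon, so no measured step bears on this change, and the step from compound 2 to compound 3 says nothing about it. The expectation therefore rests on the value of compound 2 alone and on the loss of the one hydrogen-bond donor that the counted difference shows. With nothing to anchor the direction, a drop of moderate size is the estimate, as the expected step of a number 1.00 log units lower from compound 2 to compound 4 (beyond the scatter) states. Compound 4 is thus expected to give 7.9 in this assay, within a wide range from 6.5 to 9.3.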

Compound 4, negative logarithm of the antagonist equilibrium constant: 8.1
For compound 4 the middle estimate is 0.20 log units below the measured one, within the range that was stated.
By their numbers in this assay, from the lowest: compound 4; then compound 2; then compounds 3 and 1 (each within the scatter of the next).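

In this assay, for the compounds shown here, the change at this carbonyl carbon gives the first measured step at this place, a number 0.80 log units lower from compound 2 to compound 4 (beyond the scatter), so what sits here does affect the read-out, although the earlier compounds, which all carry the same group, could not show this. The hydrogen-bond donor of ((2-methylphenyl)sulfonyl)amino is absent from cyano(phenylsulfonyl)methyl, yet compound 4 still gives 8.1, so among the compounds shown a number of this order does not depend on keeping that donor. Nothing measured here explains the size or the direction of the step.

The replacement alters several things in a single step, since the amino link, the methyl on the aromatic ring and the nitrile all differ, and the compounds shown cannot separate their shares of the step. On these data alone, it also remains open where a simple phenylsulfonylamino group or a carboxylic acid at this place would fall relative to compound 2 and compound 4, and whether cyano(phenylsulfonyl)methyl would bring a similar step on the cores of compound 1 and compound 3.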